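The source may hold more compounds than are shown below. What is called first, only, known or untested is meant among the compounds shown, and "the series" means these compounds.

Three compounds built on one shared core were tested in an assay on isolated protein for inhibition of Fatty-acid amide hydrolase 1 (Homo sapiens); a higher number here means a weaker inhibitor, a lower number a stronger inhibitor. Compound 1 `O=C(CCCC1CCN(C(=O)C2CCCCC2)CC1)c1ncco1` gives 45 nM, compound 2 `CC(C)C(=O)N1CCC(CCCC(=O)c2ncco2)CC1` gives 250 nM, and compound 3 `CC(C)OC(=O)N1CCC(CCCC(=O)c2ncco2)CC1` gives 4 nM, the lowest number of the three. Every measured step changes only the group attached to the carbonyl carbon: a 5.6-fold higher number from compound 1 to compound 2 (0.74 log units; beyond the scatter), an 11-fold lower number from compound 1 to compound 3 (1.05 log units; beyond the scatter) and a 63-fold lower number from compound 2 to compound 3 (1.80 log units; beyond the scatter). Compound 4 `O=C(CCCC1CCN(Cc2ccccc2Cl)CC1)c1ncco1` instead carries 2-chlorobenzyl in place of isopropoxycarbonyl on an amine nitrogen in a ring. Going by the values given here, no measured step removes the carbonyl itself, so the three steps show only that this part of the molecule moves the number strongly. Because compound 3 already holds the lowest value at 4 nM, compound 4 is expected to show a higher number. For compound 4 an estimate of 150 nM is made, with a range from 20 nM to 1500 nM. The expected step is a 38-fold higher number from compound 3 to compound 4 (1.57 log units; beyond the scatter).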

Compound 4, half-maximal inhibitory concentration: 260 nM
Beside the measured number, compound 4's estimate is 1.7-fold (0.24 log units) below it; measured number inside the range.
By their numbers in this assay, from the lowest: compound 3; then compound 1; then compounds 2 and 4 (each within the scatter of the next).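

Replacing the carbonyl-bearing group on the amine nitrogen with 2-chlorobenzyl takes the carbonyl away from this position, and the number rises (a 65-fold higher number from compound 3 to compound 4 (1.81 log units; beyond the scatter)) and (a 5.8-fold higher number from compound 1 to compound 4 (0.76 log units; beyond the scatter)). Yet losing that carbonyl does not alone set the number, since compound 2 keeps its carbonyl and the step to the group without one shows no real difference (a 1.0-fold higher number from compound 2 to compound 4 (0.02 log units; within the scatter)). Nothing available explains these differences.

As far as these compounds go, whether the chlorine matters remains open, as a plain benzyl group would be needed to test it. It is also unknown how a cyclohexyloxycarbonyl group would compare with the isopropoxycarbonyl of compound 3.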